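This account rests on a few compounds, and the source may have more. Where it says the series, first, only, none or still open, it means among the compounds named here.

Of the compounds shown here, three built on one shared core have been measured in an assay on SHEP1 cells for agonist activity at Neuronal acetylcholine receptor; alpha4/beta2 (Homo sapiens), read by FLIPR and calcium flux; on this read-out lower numbers stand for an effect already at smaller amounts and higher numbers for an effect only at larger amounts of compound. Compound 1 `C[C@@H]1C[C@@H]1C(=O)N1CC2CNCC2C1` gives 1200 nM, compound 2 `C[C@H]1C[C@@H]1C(=O)N1CC2CNCC2C1` gives 5600 nM, and compound 3 `CC(=O)N1CC2CNCC2C1` gives 2600 nM. Compound 3 thus stands second highest of the three numbers, with a 2.2-fold higher number from compound 1 to compound 3 (0.34 log units; beyond the scatter) and a 2.2-fold lower number from compound 2 to compound 3 (0.33 log units; beyond the scatter). Compound 4 `CCC(=O)N1CC2CNCC2C1` differs from compound 3 by methyl in place of hydrogen on a saturated chain carbon bound to a carbonyl carbon, so only those two measured steps bear on it, and both were modest and pointed in opposite directions. A small change is therefore expected in this assay, not beyond the scatter, as a 1.2-fold lower number from compound 3 to compound 4 (0.07 log units; within the scatter). Compound 4 is estimated at 2200 nM, with a range from 900 nM to 5500 nM.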

Compound 4, half-maximal effective concentration: 1300 nM
Beside the measured number, compound 4's estimate is 1.7-fold (0.23 log units) above it; the range from low to high includes it.
By their numbers in this assay, from the lowest: compounds 1, 4 and 3 (each within the scatter of the next, the first and the last beyond it); then compound 2.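

In this assay, methyl in place of hydrogen on the saturated chain carbon bound to the carbonyl carbon, the change from acetyl to propanoyl, stays within the scatter (a 2.0-fold lower number from compound 3 to compound 4 (0.30 log units; within the scatter)). On the carbonyl carbon, ethyl matches the 2-methylcyclopropyl group in one drawn configuration (a 1.1-fold higher number from compound 1 to compound 4 (0.03 log units; within the scatter)) but not in the other (a 4.3-fold lower number from compound 2 to compound 4 (0.63 log units; beyond the scatter)), so the three-membered ring is not required to reach that level. Nothing given here explains these steps. On these data alone, whether a longer chain, such as butanoyl, or a branched isopropyl group would shift the number remains open.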